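The source may report more compounds than this note shows. Statements on the series, on what has been measured and on what is new or still open speak of the compounds shown alone.

Measured compounds:
- compound 1 `COc1cc(-c2cc(/C=C/C(=O)c3ccc(N)cc3)[nH]n2)cc(OC)c1OC` gives 97%
- compound 2 `COc1ccc(-c2cc(/C=C/C(=O)c3ccc(OC)c(OC)c3)[nH]n2)cc1` gives 95%
- compound 3 `COc1ccc(C(=O)/C=C/c2cc(-c3cc(OC)c(OC)c(OC)c3)n[nH]2)cc1` gives 99%

All three numbers come from a functional assay on PC-3 cells (Homo sapiens) for cytotoxicity, read by sulforhodamine B assay, with a stated time of 48 h, tested at 0.01 uM; on this read-out higher numbers stand for a weaker effect at the one concentration tested and lower numbers for a stronger effect. Compound 3 holds the highest of the three numbers, but its nearest neighbour compound 1 sits only a number 2 percentage points higher from compound 1 to compound 3 (within the scatter) away, and compound 2 also lies within the scatter of compound 3, so no order among the three can be claimed; the whole set sits close to no effect at the single concentration tested.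

Compound 4 `COc1cc(-c2cc(/C=C/C(=O)c3ccc(F)c(F)c3)[nH]n2)cc(OC)c1OC` is not yet measured. It differs from compound 3 as follows: 3,4-difluorophenyl in place of 4-methoxyphenyl on a carbonyl carbon

Going by the values given here, only one step is known, the change from compound 1 to compound 3, which was a number 2 percentage points higher from compound 1 to compound 3 (within the scatter) and concerned a methoxy replacing an amino on an aromatic carbon. That step does not touch the aryl group on the carbonyl carbon and so bears on the present change only indirectly: it shows that at least one peripheral change left the read-out in this assay unmoved. Compound 2, which also carries a different aryl pattern, gives a number within the scatter of compound 3. Among the compounds with values here, no measured pair tests a difluorophenyl in place of a methoxyphenyl on the carbonyl carbon.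

With all three measured compounds clustered near the ceiling of the read-out, no step beyond the scatter is expected for the change to compound 4; the expected step is a number 3 percentage points lower from compound 3 to compound 4 (within the scatter). Compound 4 is therefore estimated at 96%, with a range from 86% to 103%.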

Compound 4, a percentage reported as activity, at one concentration (the size of the read-out at that concentration, not a potency): 98%
The estimate for compound 4 lay 2 percentage points below the measured number, and the stated range covers the measured number.
By their numbers in this assay, from the lowest: compounds 2, 1, 4 and 3 (each within the scatter of the next).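

Going by these compounds alone, at the aryl group on the carbonyl carbon, 3,4-difluorophenyl in place of 4-methoxyphenyl gives a number 1 percentage points lower from compound 3 to compound 4 (within the scatter) in this assay, the first measured exchange of this aryl group with both of its substituents changed. The same place also carries 3,4-difluorophenyl in place of 4-aminophenyl, with a number 1 percentage points higher from compound 1 to compound 4 (within the scatter), so the 4-aminophenyl, 4-methoxyphenyl and 3,4-difluorophenyl forms on the shared core all lie within the scatter of one another, and at the single concentration tested this position shows no dependence on the aryl group among these three. No supporting measurement bears on this flat result.

With every number close to no effect, a single low concentration cannot show whether these aryl groups would differ at concentrations where the series has a clear effect, so the flatness says little beyond the lack of a stronger or weaker effect at the one concentration tested. Also open, as far as these compounds go, is whether a more distant change on the carbonyl carbon would move the read-out, such as a cyclohexyl or a pyridyl ring in place of the phenyl, or a carboxylic acid on the phenyl ring.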